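The compounds below may be only part of what the source reports. "The series", "measured", "known", "first", "only" and "open" are said of these compounds alone.

Measured so far:
compound 1, `Nc1ccc(OCc2ccccc2)c2ccccc12`, in a functional assay, with a stated time of 15 min (on this read-out lower numbers stand for an effect already at smaller amounts and higher numbers for an effect only at larger amounts of compound), gives 7000 nM
compound 2, `Nc1ccc(O)c2ccncc12`, gives 19000 nM
compound 3, `NC(=O)c1ccc(O)c2ccccc12`, gives 430000 nM

In this assay compound 3 carries the highest of the three numbers; its nearest neighbour is compound 2, and the gap to compound 1 is wider still, both gaps beyond the scatter. Compound 4, `CN(C)c1ccc(O)c2ccccc12`, has not yet been measured. It differs from compound 3 in one place: dimethylamino in place of carbamoyl on an aromatic carbon, with the carbamoyl leaving and the dimethylamino entering para to the hydroxy group. Among the compounds with values here, no step between two measured compounds is known, so the size of this step has no direct precedent. Compound 1 and compound 2, both without a carbamoyl, give far lower numbers than compound 3, so a sizeable drop is expected, a 22-fold lower number from compound 3 to compound 4 (1.33 log units; beyond the scatter). Compound 4 is therefore estimated at 20000 nM, within a range from 4000 nM to 100000 nM.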

Compound 4, half-maximal effective concentration: 18000 nM
The estimate for compound 4 lay 1.1-fold (0.05 log units) above the measured number; the range from low to high includes it.
By their numbers in this assay, from the lowest: compound 1; then compounds 4 and 2 (each within the scatter of the next); then compound 3.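

Within the data shown here, replacing the carbamoyl para to a hydroxy group with dimethylamino gives a 24-fold lower number from compound 3 to compound 4 (1.38 log units; beyond the scatter) in this assay and is the first direct measure at this position: the group here matters a great deal. The two groups have the same number of heavy atoms, so that count does not decide the result, but only the carbamoyl has a hydrogen-bond donor and a double bond. Nothing measured here explains the change. This single pair cannot show which of those differences counts. On these data alone, how a carboxylic acid or a methylamino group would fare at this position remains open.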